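This account rests on a few compounds, and the source may have more. Where it says the series, first, only, none or still open, it means among the compounds named here.

The measured compounds and their values:

Compound 1 `CC1(C)S[C@@H]2/C(=C\C(=O)c3ccco3)C(=O)N2[C@H]1C(=O)OC(c1ccccc1)c1ccccc1` gives 61500 nM in a functional assay on NCI-H1299 cells (Homo sapiens) for cytotoxicity, read by MTT assay, with a stated time of 48 h; a lower number here means a stronger inhibitor, a higher number a weaker inhibitor.
Compound 2 `CC1(C)S[C@@H]2/C(=C\C(=O)OC(c3ccccc3)c3ccccc3)C(=O)N2[C@H]1C(=O)OC(c1ccccc1)c1ccccc1` gives 22400 nM in this assay.
Compound 3 `CC1(C)S[C@@H]2/C(=C\C(=O)c3ccc(F)cc3)C(=O)N2[C@H]1C(=O)OC(c1ccccc1)c1ccccc1` gives 25200 nM in this assay.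

Among these three numbers compound 3 stands second highest. Its nearest neighbour is compound 2, whose value lies within the scatter of that of compound 3; the furthest is compound 1, whose value lies beyond the scatter above it.

Compound 4 `CC1(C)S[C@@H]2/C(=C\C(=O)OCc3ccccc3)C(=O)N2[C@H]1C(=O)OC(c1ccccc1)c1ccccc1` differs from compound 3 in one place: benzyloxy in place of 4-fluorophenyl on a carbonyl carbon. Going by the values given here, one measured step bears on this position, the change at the same carbonyl carbon from compound 1 to compound 3, which gave a 2.4-fold lower number from compound 1 to compound 3 (0.39 log units; beyond the scatter). Compound 2 also carries an ester oxygen at this carbonyl, and its value and that of compound 3 sit within the scatter of each other. A step of no more than modest size, and none beyond the scatter, is therefore expected in this assay from compound 3 to compound 4, namely a 1.0-fold lower number from compound 3 to compound 4 (0.00 log units; within the scatter). Compound 4 is estimated at 25000 nM, with a range from 10000 nM to 60000 nM.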

Compound 4, half-maximal inhibitory concentration: 9400 nM
Compound 4: the middle estimate sits 2.7-fold (0.42 log units) above what was measured; measured number below the stated range.
By their numbers in this assay, from the lowest: compound 4; then compounds 2 and 3 (each within the scatter of the next); then compound 1.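

In this assay the benzyloxy group on this carbonyl carbon gives a 2.7-fold lower number from compound 3 to compound 4 (0.43 log units; beyond the scatter) and so shows that an ester oxygen at this carbonyl does not by itself leave a compound level with compound 3. The two esters also part, with a 2.4-fold lower number from compound 2 to compound 4 (0.38 log units; beyond the scatter) as hydrogen replaces phenyl on the saturated chain carbon, so the earlier match between compound 2 and compound 3 does not extend to every ester. Set against furan-2-yl, benzyloxy gives a 6.5-fold lower number from compound 1 to compound 4 (0.82 log units; beyond the scatter) as the largest step among these compounds and widens the span seen at this carbonyl carbon.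

Going by these compounds, whether a phenethyloxy group, an amine or a carboxylic acid in place of benzyloxy on this carbonyl carbon would lower the number further stays open. No measurement given here speaks to the reason for these steps.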